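The compounds below may be only part of what the source reports. "The series", "measured", "known", "first", "only" and "open" are said of these compounds alone.

Going by the values given here, in an in vitro ADME assay on microsomes from liver (Simiiformes) (on this read-out higher numbers stand for a longer-lived compound and lower numbers for a shorter-lived compound), compound 3 (`Cc1cc(CCCOc2c(C)cc(-c3noc(C(Cl)(Cl)Cl)n3)cc2C)on1`) gives 0.183 h, the lower of the two actual numbers measured so far. The other number comes from compound 1 (`CCc1cc(CCCOc2c(C)cc(-c3noc(C4CC4)n3)cc2C)on1`), which gives 0.9 h. Compound 2 (`Cc1cc(-c2noc(C3CC3)n2)cc(C)c1OCCCc1cc(CO)no1`) gives > 2.5 h, and this is a limit of the assay rather than a number.

The next compound, compound 4 (`Cc1cc(CCCOc2c(C)cc(-c3noc(C(F)F)n3)cc2C)on1`), has difluoromethyl in place of trichloromethyl on an aromatic carbon of the five-membered aromatic ring: difluoromethyl in place of trichloromethyl on an aromatic carbon. Among the compounds with values here, no measured step tests this change directly. Within the data shown here, the only measured step puts hydroxy in place of methyl on a saturated chain carbon bound to an aromatic carbon, at a different place in the molecule, and it amounts to an at least 2.7-fold higher number from compound 1 to compound 2 (0.44 log units; beyond the scatter). That step shows that a single change can move this read-out beyond the scatter, but it says nothing about the size of this one.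

Compound 1 carries no trichloromethyl and gives 0.9 h, so a number nearer to that value seems likely for compound 4, although compound 1 also differs from compound 3 elsewhere. The expected change, with a longer half-life, is a 4.4-fold higher number from compound 3 to compound 4 (0.64 log units; beyond the scatter). For compound 4 the estimated half-life is 0.8 h, with an expected range of 0.3 h to 2 h.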

Compound 4, half-life: 1.42 h
The estimate for compound 4 lay 1.8-fold (0.25 log units) below the measured number; measured number inside the range.
By their numbers in this assay, from the lowest: compound 3; then compounds 1 and 4 (each within the scatter of the next). At a limit, above all of these: compound 2.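

In this assay, difluoromethyl in place of trichloromethyl gives a 7.8-fold higher number from compound 3 to compound 4 (0.89 log units; beyond the scatter). Going by these compounds alone, compound 3 and compound 4 differ in this one place only, so this is the first direct reading of the group on an aromatic carbon of the five-membered aromatic ring with 2 nitrogen and 1 oxygen, and it shows that this site, like the chain carbon changed earlier, can move the half-life beyond the scatter. The measurements shown give the size of this step but no reason for it.

On these data alone, with a single pair at this site, it stays open whether the step reflects the loss of trichloromethyl or the arrival of difluoromethyl, and where other groups, such as trifluoromethyl, a plain methyl or an amine, would fall on the same carbon. As far as these compounds go, it also stays open whether the same exchange would give a step of similar size in a molecule that carries the hydroxy group of compound 2, and whether the two changes would add up.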